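A few compounds are considered here, and "the series" means these few. Any claim that something is new, unique, unknown or untested is made for them only; others in the source may bear on it.

Compound 1 `CCc1nc2ccccc2n1CCCCOc1ccccc1` and compound 2 `CCc1nc2ccccc2n1CCCCOc1cccc(C)c1` share a core and differ only in one spot: methyl in place of hydrogen on an aromatic carbon. In an ADME assay on Vero cells (Chlorocebus sabaeus) for cytotoxicity, read by luminescence, with a stated time of 2 days (a lower number here means that less compound is tolerated, a higher number that more compound is tolerated), compound 1 gives 21 uM, and compound 2 gives 19 uM; the step is a 1.1-fold lower number from compound 1 to compound 2 (0.04 log units; within the scatter). Compound 3 `CCc1nc2cnccc2n1CCCCOc1ccccc1` carries a different core; how the two cores differ is not broken down here, and in this assay compound 3 gives "not determined" (no result reported), so compound 3 has no single number there. Compound 4 `CCc1nc2cnc(C)cc2n1CCCCOc1ccccc1` differs from compound 3 in one spot: methyl in place of hydrogen on an aromatic carbon. This is the same kind of change as from compound 1 to compound 2, but not the same, since there the methyl sits on a ring of carbon only, meta to a large group, while here it sits on a ring with one nitrogen, next to the ring nitrogen. Because a 1.1-fold lower number from compound 1 to compound 2 (0.04 log units; within the scatter) lay within the scatter, a similarly small step is expected here, and compound 4 is expected to give about 20 uM in this assay, likely between 8 uM and 50 uM.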

Compound 4, half-maximal toxic concentration: 71 uM
For compound 4 the middle estimate is 3.6-fold (0.55 log units) below the measured one; measured number above the stated range.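

Among these compounds, no step from compound 3 to compound 4 can be read: compound 3 has no single number in this assay. Going by these compounds, whether the methyl of compound 4 shifts that number stays open. No evidence shown bears on this result.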